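The source may report more compounds than this note shows. Statements on the series, on what has been measured and on what is new or still open speak of the compounds shown alone.

Measured in an ADME assay on HepG2 cells (Homo sapiens) for cytotoxicity, read by MTT assay, with a stated time of 7 days; a lower number here means a stronger inhibitor, a higher number a weaker inhibitor:
Compound 1 `COc1ccc(C2CC(c3ccc(O)cc3)=NN2C(=O)c2cccnc2)cc1OC`: 53600 nM
Compound 2 `O=C(c1cccnc1)N1N=C(c2ccc(O)cc2)CC1c1ccc([N+](=O)[O-])cc1`: 18600 nM

Of these two compounds, compound 2 has the lower number, so it stands as the stronger inhibitor in this assay. Compound 3 `Cc1cc(C)c(C2CC(c3ccc(O)cc3)=NN2C(=O)c2cccnc2)c(C)c1` is the next to be measured. It carries 2,4,6-trimethylphenyl in place of 4-nitrophenyl on a saturated ring carbon. For the measured compounds named here, one measured step bears on this change, since it alters the group at the same ring carbon: a 2.9-fold lower number from compound 1 to compound 2 (0.46 log units; beyond the scatter). Going by the values given here, that step is modest and beyond the scatter, and it is the only guide available. Like compound 1, compound 3 lacks the 4-nitrophenyl group, so a modest move back towards the value of compound 1, 53600 nM, is expected in this assay. The expected change is a 1.6-fold higher number from compound 2 to compound 3 (0.21 log units; within the scatter). Compound 3 is estimated at 30000 nM, with an expected range from 12000 nM to 75000 nM.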

Compound 3, half-maximal inhibitory concentration: 54500 nM
For compound 3 the middle estimate is 1.8-fold (0.26 log units) below the measured one, and the stated range covers the measured number.
By their numbers in this assay, from the lowest: compound 2; then compounds 1 and 3 (each within the scatter of the next).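

In this assay, 2,4,6-trimethylphenyl in place of 4-nitrophenyl on the saturated ring carbon gives a 2.9-fold higher number from compound 2 to compound 3 (0.47 log units; beyond the scatter), whereas 2,4,6-trimethylphenyl in place of 3,4-dimethoxyphenyl gives a 1.0-fold higher number from compound 1 to compound 3 (0.01 log units; within the scatter). Among these three compounds, 4-nitrophenyl therefore stands alone at this position: compound 2 is set apart from both others, while two differently substituted phenyl groups, one with methyl groups and one with methoxy groups, give numbers within the scatter of each other. No measurement is available that explains this difference.

From the compounds shown here alone, it remains open whether a phenyl ring carrying a nitrile or an amine at this carbon would match compound 2 or compounds 1 and 3. The 4-hydroxyphenyl and (pyridin-3-yl)carbonyl groups are the same throughout, so whether the step holds with other groups in those places is also unknown.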